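Naphthyl in Place of a Phenol on the Small Ring

The source may report more compounds than this note shows. Statements on the series, on what has been measured and on what is new or still open speak of the compounds shown alone.

Three compounds have been tested in a functional assay on MCF7 cells (Homo sapiens) for antiproliferative activity, read by MTT assay; a higher number here means a weaker inhibitor, a lower number a stronger inhibitor:

Compound 1, `COc1ccc([C@@H]2C(c3ccc(C)s3)C(=O)N2c2cc(OC)c(OC)c(OC)c2)cc1`, gives 250 nM.
Compound 2, `COc1ccc([C@@H]2[C@@H](c3cccs3)C(=O)N2c2cc(OC)c(OC)c(OC)c2)cc1O`, gives 7 nM.
Compound 3, `COc1ccc(C2/C(=C/c3ccc(C)s3)C(=O)N2c2cc(OC)c(OC)c(OC)c2)cc1`, gives 580 nM.

Compound 2 has the lowest number of the three, and it stands apart: compound 1 is the nearest, and its number is higher by a gap that lies beyond the scatter, while compound 3 is furthest away, again well beyond the scatter. Compound 2 is therefore the strongest inhibitor among the measured compounds.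

Compound 4, `COc1cc(N2C(=O)[C@H](c3cccs3)[C@H]2c2cccc3ccccc23)cc(OC)c1OC`, has not yet been measured. It differs from compound 2 in one place: naphthalen-1-yl in place of 3-hydroxy-4-methoxyphenyl on a saturated ring carbon. The 3-hydroxy-4-methoxyphenyl group that leaves carries one hydrogen-bond donor and two acceptors; the naphthalen-1-yl group that enters carries none.

Going by the values given here, no single-point step between measured compounds shows what this swap does, so the expectation rests on compound 2 alone. Compound 1, which also lacks the hydroxyl, gives 250 nM, and a weaker inhibitor seems likely. The step from compound 2 to compound 4 is expected to be a 21-fold higher number from compound 2 to compound 4 (1.33 log units; beyond the scatter), a sizeable rise. Compound 4 is estimated to give 150 nM, with a plausible range from 20 nM to 1200 nM.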

Compound 4, half-maximal inhibitory concentration: 620 nM
Compound 4: middle estimate off by 4.1-fold (0.62 log units), on the low side, within the range that was stated.
By their numbers in this assay, from the lowest: compound 2; then compound 1; then compounds 3 and 4 (each within the scatter of the next).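

In this assay, going by these compounds alone, putting naphthalen-1-yl in place of 3-hydroxy-4-methoxyphenyl on this saturated ring carbon gives an 89-fold higher number from compound 2 to compound 4 (1.95 log units; beyond the scatter), the first single-change step at this position. The position is therefore far from indifferent to this swap: the group with one six-membered aromatic ring, one hydrogen-bond donor and two acceptors gives a much stronger inhibitor than the group with two aromatic rings and no donors or acceptors. No measurement is at hand to explain the loss, and this one step changes the ring count, the hydroxyl and the methoxy together.

It remains open which of these differences accounts for the step. A 3-amino-4-methoxyphenyl group or a naphthalen-2-yl group at this position, on the core of compound 2, would help to separate them.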